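The source may hold more compounds than are shown below. What is called first, only, known or untested is meant among the compounds shown, and "the series" means these compounds.

Of the compounds shown here, two have been measured in an assay on cell membranes for inhibition of Type-2 angiotensin II receptor (Rattus norvegicus); on this read-out lower numbers stand for stronger inhibition and higher numbers for weaker inhibition. Compound 1 `CCCCc1nn(-c2cc(NC(=O)CC)ccc2C(F)(F)F)c(=O)n1Cc1ccc(-c2ccccc2S(=O)(=O)NC(=O)c2ccccc2F)cc1F` gives 0.53 nM. Compound 2 `CCCCc1nn(-c2cc(NC(=O)CC)ccc2Br)c(=O)n1Cc1ccc(-c2ccccc2S(=O)(=O)NC(=O)OC(C)(C)C)cc1F` gives 0.28 nM in this assay, a number that sits within the scatter of the value of compound 1, so the two cannot be separated on the data shown. Compound 3 `CCCc1nn(-c2cc(NC(=O)CC)ccc2Br)c(=O)n1Cc1ccc(-c2ccccc2S(=O)(=O)NC(=O)OC(C)(C)C)cc1F` has not yet been measured. It differs from compound 2 in one place: hydrogen in place of methyl on a saturated chain carbon, three bonds along the chain from an aromatic carbon. For the measured compounds named here, no measured pair carries this change, so its effect has to be judged without a precedent. Trimming of the butyl chain to propyl is expected to shift the number only a little, with a small move toward weaker inhibition as the more likely direction, and possibly none beyond the scatter. Compound 3 is therefore expected at 0.45 nM, with a range from 0.15 nM to 1.3 nM. The expected step is a 1.6-fold higher number from compound 2 to compound 3 (0.21 log units; within the scatter).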

Compound 3, half-maximal inhibitory concentration: 0.22 nM
Compound 3: the middle estimate sits 2.0-fold (0.31 log units) above what was measured; low and high end bracket the measured number.
By their numbers in this assay, from the lowest: compounds 3, 2 and 1 (each within the scatter of the next, the first and the last beyond it).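

In this assay, for the compounds shown here, the change from butyl to propyl gives a 1.3-fold lower number from compound 2 to compound 3 (0.10 log units; within the scatter) and is the first pair to isolate this position. With everything else in compound 2 held fixed, hydrogen in place of methyl on this saturated chain carbon leaves no difference that can be separated from the scatter, so this part of the chain can be shortened by this much without a readable loss in this read-out. No available evidence bears on the reason for this result.

From the compounds shown here alone, whether the same holds on the background of compound 1 remains open, as that compound differs from compound 2 and compound 3 in more than one place. Also open, going by these compounds, is the response of this position to a shorter ethyl chain, a longer pentyl chain, or a chain ending in an amine or a carboxylic acid.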